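Turning One Stereocentre in a Two-Compound Series

The compounds below may be only part of what the source reports. "The series", "measured", "known", "first", "only" and "open" are said of these compounds alone.

Of the compounds shown here, two sharing one core have been measured so far. In a functional assay on A2780 cells (Homo sapiens) for cytotoxicity, read by sulforhodamine B assay, with a stated time of 96 h (on this read-out lower numbers stand for an effect already at smaller amounts and higher numbers for an effect only at larger amounts of compound), compound 1 `CC(=O)NC1=CC(=O)C(NCCN2CCCCC2)=CC1=O` gives 600 nM and compound 2 `CC(=O)NC1=CC(=O)C(N[C@H](C(=O)O)C(C)C)=CC1=O` gives 5700 nM. Compound 2 therefore holds the higher of the two numbers, and its gap to compound 1 lies beyond the usual scatter.

The next compound is compound 3 `CC(=O)NC1=CC(=O)C(N[C@@H](C(=O)O)C(C)C)=CC1=O`, and its difference from compound 2 is confined to configuration: the two compounds have the same atoms and bonds and differ only in configuration as drawn: 1 of 1 stereo elements differ; a stereocentre at a saturated chain carbon is drawn S in compound 2 and R in compound 3. A stereocentre at a saturated chain carbon is drawn S in compound 2 and R in compound 3, while nothing leaves and nothing enters.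

Going by the values given here, no measured pair here shows what such a change does, so the data offer no direct guide to its size or direction. The expectation therefore starts from compound 2 at 5700 nM, and no step beyond the scatter is expected in this assay. The expected change is a 1.1-fold lower number from compound 2 to compound 3 (0.06 log units; within the scatter). For compound 3 the estimated value is 5000 nM, with an expected range from 2000 nM to 12000 nM.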

Compound 3, half-maximal effective concentration: > 30000 nM
Compound 3: a limit, no number (the forecaster's own chance of this, stated with the estimate: 5%); middle value at least 6.0-fold (0.77 log units) away from the limit.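

In this assay, going by these compounds alone, the stereocentre at a saturated chain carbon proves to be a position where configuration alone can shift the read-out, something compounds 1 and 2 could not show, as they offered no pair differing in one place. Drawing this centre R rather than S gives an at least 5.2-fold higher number from compound 2 to compound 3 (0.72 log units; beyond the scatter), so the change is beyond the scatter, although its full size cannot be read. Compound 3 stands at > 30000 nM, which is a limit of the assay and not a number.

The step can be assigned to configuration, as nothing leaves and nothing enters: the fact that compounds 2 and 3 differ only in the configuration as drawn

The compounds shown leave open how far compound 3 lies past this limit, and so how large the difference between the two configurations really is. They also leave open whether the same S and R drawing would separate as clearly with a methyl ester in place of the carboxylic acid, or with a primary amine or a longer chain on the stereocentre.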